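Aryl exchange on the shared core: the next step

The source may report more compounds than this note shows. Statements on the series, on what has been measured and on what is new or still open speak of the compounds shown alone.

In an ADME assay on cells (Splenocyte, Mus musculus, strain BALB/c) for cytotoxicity, read by thymidine incorporation, with a stated time of 24 h (a higher number here means a weaker inhibitor, a lower number a stronger inhibitor), compound 3 `O=C(CCN1CCN(c2ccnc3cc(Cl)ccc23)CC1)N/N=C/c1ccc([N+](=O)[O-])cc1` gives 12100 nM and compound 1 `COc1cc(/C=N/NC(=O)CCN2CCN(c3ccnc4cc(Cl)ccc34)CC2)ccc1O` gives 9400 nM, two values within the scatter of each other. Within the data shown here, compound 2 `O=C(CCN1CCN(c2ccnc3cc(Cl)ccc23)CC1)N/N=C/c1c[nH]c2ccccc12` gives 5700 nM and is the only one apart from compound 3.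

Compound 4 `O=C(CCN1CCN(c2ccnc3cc(Cl)ccc23)CC1)N/N=C/c1ccccc1Cl` has 2-chlorophenyl in place of 4-nitrophenyl on a carbon with a double bond to nitrogen. Exchanges at this place have so far moved the number little (a 1.6-fold lower number from compound 1 to compound 2 (0.22 log units; within the scatter)), (a 1.3-fold higher number from compound 1 to compound 3 (0.11 log units; within the scatter)) and (a 2.1-fold higher number from compound 2 to compound 3 (0.33 log units; beyond the scatter)). Among the measured compounds shown here, no measured compound carries 2-chlorophenyl. In this assay no step beyond the scatter is therefore expected, and the estimated step is small (a 1.3-fold lower number from compound 3 to compound 4 (0.11 log units; within the scatter)). The estimate for compound 4 is 9500 nM (range 5000 nM to 18000 nM).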

Compound 4, half-maximal inhibitory concentration: 10800 nM
The estimate for compound 4 lay 1.1-fold (0.06 log units) below the measured number, and the stated range covers the measured number.
By their numbers in this assay, from the lowest: compounds 2, 1, 4 and 3 (each within the scatter of the next, the first and the last beyond it).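

In this assay, 2-chlorophenyl in this place on a carbon with a double bond to nitrogen gives a number within the scatter of all three earlier groups (a 1.1-fold lower number from compound 3 to compound 4 (0.05 log units; within the scatter)) (a 1.1-fold higher number from compound 1 to compound 4 (0.06 log units; within the scatter)) (a 1.9-fold higher number from compound 2 to compound 4 (0.28 log units; within the scatter)). Among these compounds, compound 4 thus sits within the scatter of both compound 2 and compound 3, the only pair printed as beyond it, so these four compounds do not fall into two separate groups. No evidence is available on what sets these numbers.

Still open, from the compounds shown here alone, is whether an amine or a carboxylic acid in place of the aryl group would move the number further. A longer chain in the shared core is equally untested in the compounds shown.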